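The compounds below may be only part of what the source reports. "The series", "measured", "known", "first", "only" and "open" are said of these compounds alone.

Three analogues built on one shared core have been measured in a functional assay on A549 cells (Homo sapiens) for antiproliferative activity, read by MTT assay, with a stated time of 48 h, in the presence of a further agent that is not named here; a lower number here means a stronger inhibitor of growth, a higher number a weaker inhibitor of growth. Compound 1 `O=C(NOCc1ccc(Cl)cc1Cl)c1cn(-c2ccccc2)nc1-c1ccccc1` gives 7350 nM. Compound 2 `COc1ccc(-c2nn(-c3ccccc3)cc2C(=O)NOCc2ccccc2F)cc1` gives 2160 nM, and compound 3 `COc1ccc(-c2nn(-c3ccccc3)cc2C(=O)NOCc2ccccc2Cl)cc1` gives 2450 nM. Among these three numbers compound 3 stands second highest: its nearest neighbour is compound 2, and the step of a 1.1-fold higher number from compound 2 to compound 3 (0.05 log units; within the scatter) lies within the scatter, so the two cannot be told apart. Compound 1 sits furthest away, with a number that is clearly higher than that of compound 3.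

Compound 4 `COc1ccc(-c2nn(-c3ccccc3)cc2C(=O)NOCc2ccc(Cl)cc2Cl)cc1` differs from compound 3 in one place: chloro in place of hydrogen on an aromatic carbon, which turns a 2-chlorobenzyl group into a 2,4-dichlorobenzyl group. Within the data shown here, no measured pair shows exactly this change. Among the measured compounds shown here, the only measured step, from compound 2 to compound 3, swaps one halogen for another and was within the scatter. Compound 1 carries the same 2,4-dichlorobenzyl group but differs from compound 3 in a second place as well, so its higher number can only hint at the direction. A moderate rise in the number, beyond the scatter but not large, is expected for compound 4, a step of a 1.6-fold higher number from compound 3 to compound 4 (0.19 log units; within the scatter), giving an estimated 3800 nM with a range from 1500 nM to 9000 nM.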

Compound 4, concentration for 50% growth inhibition: 3830 nM
Beside the measured number, compound 4's estimate is 1.0-fold (0.00 log units) below it, and the stated range covers the measured number.
By their numbers in this assay, from the lowest: compounds 2, 3, 4 and 1 (each within the scatter of the next, the first and the last beyond it).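

In this assay, the second chloro on the 2-chlorobenzyl group, placed para to a large group, gives a 1.6-fold higher number from compound 3 to compound 4 (0.19 log units; within the scatter) and so cannot be told from the scatter: this aromatic carbon accepts chloro in place of hydrogen without a clear shift in growth inhibition. The other two single-place comparisons agree, since the change of 2-fluorophenyl to 2,4-dichlorophenyl gives a 1.8-fold higher number from compound 2 to compound 4 (0.25 log units; within the scatter) and methoxy in place of hydrogen on the other aromatic ring gives a 1.9-fold lower number from compound 1 to compound 4 (0.28 log units; within the scatter), both also within the scatter. No separate measurement is available to explain any of these numbers.

On these data alone, it remains open whether an amine or a carboxylic acid on this same aromatic carbon would give a step beyond the scatter. Also open, as far as these compounds go, is whether a longer chain in place of the single saturated carbon bound to the oxygen would change the number.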